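The source may hold more compounds than are shown below. What is called first, only, known or untested is meant among the compounds shown, and "the series" means these compounds.

Of the compounds shown here, three have been measured in a functional assay on NCI/ADR-RES cells (Homo sapiens) for inhibition, read by sulforhodamine B assay, with a stated time of 48 h; on this read-out lower numbers stand for stronger inhibition of growth and higher numbers for weaker inhibition of growth. Compound 1 `CC1=CC[C@H](C(C)(C)N=C=S)CC1` returns only a limit, > 100000 nM. Compound 3 `CC1=CC[C@H](C(C)(C)NC(=S)N/N=C/c2cccc([N+](=O)[O-])c2)CC1` likewise returns only a limit, > 100000 nM. Within the data shown here, compound 2 `COc1ccc(/C=N/NC(=S)NC(C)(C)[C@H]2CC=C(C)CC2)cc1` is the one compound with a number, giving 43800 nM, and it therefore stands alone among the values shown, since the limit of > 100000 nM in this assay, at which 2 of the 3 values shown sit, marks where the other two sit. Compound 4 `CC1=CC[C@H](C(C)(C)NC(=S)N/N=C/c2ccco2)CC1` differs from compound 2 by furan-2-yl in place of 4-methoxyphenyl on a carbon with a double bond to nitrogen. Among the measured compounds shown here, no measured pair shows what this exchange does in this assay. Given that two of three compounds already sit at the limit, a step toward weaker inhibition, around the edge of the scatter, is expected. Compound 4 is estimated at 60000 nM, within 25000 nM to 150000 nM. The expected step is a 1.4-fold higher number from compound 2 to compound 4 (0.14 log units; within the scatter).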

Compound 4, concentration for 50% growth inhibition: 9800 nM
Estimate against measurement, compound 4: 6.1-fold (0.79 log units) above, outside the stated range (below it).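

In this assay, the place on a carbon with a double bond to nitrogen proves responsive: furan-2-yl in place of 4-methoxyphenyl brings a 4.5-fold lower number from compound 2 to compound 4 (0.65 log units; beyond the scatter) and gives the series its first readable step, one beyond the scatter. Compound 1 and compound 3 remain limits, not numbers: the limit of > 100000 nM in this assay, at which 2 of the 4 values shown sit.

On these data alone, what a thiophene or a pyridine ring would do in this place stays open. So does whether a smaller five-membered ring carrying a methyl group would keep this step.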